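A few compounds are considered here, and "the series" means these few. Any claim that something is new, unique, unknown or untested is made for them only; others in the source may bear on it.

Measured so far in a functional assay on NCI-H292 cells (Homo sapiens) for cytotoxicity, read by MTT assay, with a stated time of 72 h, tested at 10 ug/mL; a higher number here means more inhibition of growth at the concentration tested, a lower number less inhibition of growth:

Compound 1 `O=C1NC(=S)/C(=C/c2cc(Cl)cc(Cl)c2Cl)S1` gives 40.5%.
Compound 2 `O=C1NC(=S)/C(=C/c2ccccc2Br)S1` gives 36.9%.
Compound 3 `O=C1NC(=S)/C(=C/c2ccccc2Cl)S1` gives 45%.

Compound 3 stands at the top of these three numbers, but the gaps to the others lie within the usual scatter, so no ordering can be read from them. For the measured compounds named here, the step from compound 2 to compound 3, a number 8.1 percentage points higher from compound 2 to compound 3 (within the scatter), is the only single change among the measured compounds: chloro in place of bromo on an aromatic carbon. The next compound, compound 4 `O=C1NC(=S)/C(=C/c2ccccc2F)S1`, differs from compound 3 by fluoro in place of chloro on an aromatic carbon. Since the earlier halogen swap gave a number 8.1 percentage points higher from compound 2 to compound 3 (within the scatter), no step beyond the scatter is expected here, and the estimated step is a number 4 percentage points lower from compound 3 to compound 4 (within the scatter). Compound 4 is therefore expected to give about 41% in this assay, between 30% and 52%.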

Compound 4, percent growth inhibition at one concentration: 40.4%
The estimate for compound 4 lay 0.6 percentage points above the measured number; low and high end bracket the measured number.
By their numbers in this assay, from the lowest: compounds 2, 4, 1 and 3 (each within the scatter of the next).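

In this assay fluoro in place of chloro gives a number 4.6 percentage points lower from compound 3 to compound 4 (within the scatter) and fluoro in place of bromo gives a number 3.5 percentage points higher from compound 2 to compound 4 (within the scatter) on the same aromatic carbon. Fluoro, chloro and bromo at this position therefore cannot be told apart, which the single bromo-to-chloro step could not show alone. No measurement at hand offers an explanation for this result. Still open, from the compounds shown here alone, is whether a different kind of group on this carbon, such as an amine or a carboxylic acid, would give a step beyond the scatter.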